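Cytotoxicity notes: aryl exchange at the core of compound 2

The compounds below may be only part of what the source reports. "The series", "measured", "known", "first", "only" and "open" are said of these compounds alone.

Measured so far in an ADME assay on HepG2 cells (Homo sapiens) for cytotoxicity, read by luminescence, CellTiter-Glo and ATP content, with a stated time of 72 h; on this read-out lower numbers stand for an effect already at smaller amounts and higher numbers for an effect only at larger amounts of compound:
compound 1 `COc1cccc(Oc2ccc3c(NCCCNCc4cccc(OC)c4O)ccnc3c2)c1` gives 5300 nM
compound 2 `COc1cccc(CNCCCNc2ccnc3cc(Cc4ccc(F)cc4)ccc23)c1O` gives 4780 nM

Among the measured compounds shown here, compound 2 sits beside compound 1; the one measured step, a 1.1-fold lower number from compound 1 to compound 2 (0.04 log units; within the scatter), separates them by no more than repeated runs would.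

Compound 3 `COc1cccc(CNCCCNc2ccnc3cc(Oc4cccc(N(C)C)c4)ccc23)c1O` is the next member. It differs from compound 2 by 3-(dimethylamino)phenoxy in place of 4-fluorobenzyl on an aromatic carbon. For the measured compounds named here, the only step that bears on this position is the exchange of the aryl group from compound 1 to compound 2, a 1.1-fold lower number from compound 1 to compound 2 (0.04 log units; within the scatter), which stayed within the scatter. Compound 3 restores a phenoxy link at that position, as in compound 1, with 3-(dimethylamino)phenoxy in place of the 3-methoxyphenoxy of compound 1. Going by the values given here, no measured step speaks for a move beyond the scatter, so for compound 3 in this assay a flat result is expected, a 1.0-fold higher number from compound 2 to compound 3 (0.02 log units; within the scatter). Compound 3 is therefore estimated at 5000 nM, with a range from 2000 nM to 12000 nM.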

Compound 3, half-maximal effective concentration: 7300 nM
Compound 3: the middle estimate sits 1.5-fold (0.16 log units) below what was measured; low and high end bracket the measured number.
By their numbers in this assay, from the lowest: compounds 2, 1 and 3 (each within the scatter of the next).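

In this assay, 3-(dimethylamino)phenoxy in place of 4-fluorobenzyl on this aromatic carbon gives a 1.5-fold higher number from compound 2 to compound 3 (0.18 log units; within the scatter) and does not separate the two compounds, even with a different link to the aryl ring and with nitrogen and oxygen now in the group. Among the compounds shown here, the phenoxy pair adds the first comparison of two substituents on the same phenoxy ring: dimethylamino in place of methoxy gives a 1.4-fold higher number from compound 1 to compound 3 (0.14 log units; within the scatter) and is likewise unresolved. No measurement on hand explains these steps or ties them to any property of the groups.

Left open is whether a carboxylic acid on that phenoxy ring would move the number beyond the scatter. Equally open, going by these compounds, is whether a longer chain in place of the phenoxy link would do so.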